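Hydroxy for methoxy on a pyrazole-bearing diaryl urea

The compounds below may be only part of what the source reports. "The series", "measured", "known", "first", "only" and "open" are said of these compounds alone.

Of the compounds shown here, two from the study share a core and have been tested in a functional assay on DU-145 cells (Homo sapiens) for inhibition, read by sulforhodamine B assay, with a stated time of 48 h; on this read-out lower numbers stand for stronger inhibition of growth and higher numbers for weaker inhibition of growth. Compound 1, `O=C(Nc1cccc(-n2cc(-c3ccncc3)c(-c3ccc(Cl)c(O)c3)n2)c1)Nc1cccc(C(F)(F)F)c1`, carries a hydroxy and a trifluoromethylphenyl urea; in this assay compound 1 gives 1760 nM. Compound 2, `COc1cc(-c2nn(-c3cccc(NC(=O)Nc4ccc(Cl)c(Cl)c4)c3)cc2-c2ccncc2)ccc1Cl`, carries a methoxy and a dichlorophenyl urea; in this assay compound 2 gives 1520 nM. Compound 2 stands alongside compound 1: the two values lie within the usual scatter of each other, so neither can be set above the other.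

Compound 3, `O=C(Nc1cccc(-n2cc(-c3ccncc3)c(-c3ccc(Cl)c(O)c3)n2)c1)Nc1ccc(Cl)c(Cl)c1`, follows compound 2 with one change: hydrogen in place of methyl on an oxygen on an aromatic ring. Among the compounds with values here, no directly measured pair shows what this change alone does here. Within the data shown here, the only guide is that compound 1, which carries the hydroxy, gives 1760 nM, essentially level with compound 2. Compound 3 is therefore expected to show a step of a 1.1-fold lower number from compound 2 to compound 3 (0.04 log units; within the scatter) that stays within the scatter, in no clear direction. The estimate for compound 3 is 1400 nM, with a range from 600 nM to 3500 nM.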

Compound 3, concentration for 50% growth inhibition: 1500 nM
Compound 3: middle estimate off by 1.1-fold (0.03 log units), on the low side; the range from low to high includes it.
By their numbers in this assay, from the lowest: compounds 3, 2 and 1 (each within the scatter of the next).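

In this assay, within the data shown here, the first directly measured pair for hydrogen in place of methyl on an oxygen on an aromatic ring gives a 1.0-fold lower number from compound 2 to compound 3 (0.01 log units; within the scatter) and so, with the 3,4-dichlorophenyl urea held fixed, methoxy and hydroxy on the 4-chloro-3-substituted phenyl cannot be told apart at this position. Among these compounds, the same compound also gives the first pair for the other place, where 3,4-dichlorophenyl in place of 3-(trifluoromethyl)phenyl on an amide-type nitrogen, with the hydroxy held fixed, gives a 1.2-fold lower number from compound 1 to compound 3 (0.07 log units; within the scatter) and this step too stays within the scatter. Each of the two places has now been read on its own, and neither single step lies beyond the scatter in this assay.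

From the compounds shown here alone, whether an ethoxy group or a longer chain on that oxygen, an amine in place of the hydroxy, or a carboxylic acid on the urea phenyl group would separate from these values remains open, as does whether the methoxy to hydroxy swap reads the same with other urea groups. Nothing shown here bears on why these compounds read alike.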